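Replacing piperazin-1-yl on the shared core: compound 4

This account rests on a few compounds, and the source may have more. Where it says the series, first, only, none or still open, it means among the compounds named here.

Measured compounds in a functional assay on MGC-803 cells (Homo sapiens) for cytotoxicity, read by MTT assay, with a stated time of 72 h; on this read-out higher numbers stand for weaker inhibition and lower numbers for stronger inhibition:
- compound 1 `COc1ccc(Nc2cc(C)nc(SCc3nc4ccccc4[nH]3)n2)cc1` gives 51100 nM
- compound 2 `Cc1cc(NC(C)C)nc(SCc2nc3ccccc3[nH]2)n1` gives > 100000 nM, which is a limit of the assay
- compound 3 `Cc1cc(N2CCNCC2)nc(SCc2nc3ccccc3[nH]2)n1` gives > 100000 nM, which is a limit of the assay

Compound 3 stands at the limit in this assay, and it shares that limit with one other compound shown (the limit of > 100000 nM in this assay, at which 2 of the 3 values shown sit). Among the measured compounds shown here, compound 1 is the only compound with a number, and the step of an at least 1.9-fold higher number from compound 1 to compound 3 (0.29 log units; that floor lies within the scatter) likewise ends at the limit, as does an at least 1.9-fold higher number from compound 1 to compound 2 (0.29 log units; that floor lies within the scatter). Between compounds 2 and 3 the two limits leave the step unreadable a step that the two limits leave unreadable from compound 2 to compound 3.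

Compound 4 `Cc1cc(NNC(N)=S)nc(SCc2nc3ccccc3[nH]2)n1` differs from compound 3 at one place: a group of 5 heavy atoms (1 carbon, 3 nitrogen, 1 sulfur; no ring) in place of a group of 6 heavy atoms (4 carbon, 2 nitrogen; one six-membered non-aromatic ring with 2 hetero atoms), on an aromatic carbon. For the measured compounds named here, none of the measured steps touches this new group; the two steps that begin from compound 1 show only that leaving the 4-methoxyphenyl substituent has given weaker inhibition or a limit each time. For compound 4 the expected step from compound 3 is therefore an at least 1.1-fold lower number from compound 3 to compound 4 (0.04 log units; that floor lies within the scatter), which means no change beyond the scatter. The estimate for compound 4 in this assay is 90000 nM, with a range from 30000 nM to 250000 nM.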

Compound 4, half-maximal inhibitory concentration: > 100000 nM
Compound 4: no number, only a limit (the forecaster's own chance of this, stated with the estimate: 50%); at least 1.1-fold (0.04 log units) between middle value and limit.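

In this assay compound 4 also stands at a limit, so the open-chain group of 5 heavy atoms (1 carbon, 3 nitrogen, 1 sulfur; no ring) on this aromatic carbon yields no number, just as the ring of piperazin-1-yl yields none in compound 3. Among the compounds shown here, the one readable step is an at least 1.9-fold higher number from compound 1 to compound 4 (0.29 log units; that floor lies within the scatter). The steps from compound 2 and from compound 3 to compound 4 cannot be read. For the compounds shown here, compound 1, with its 4-methoxyphenyl substituent, remains the only compound with a number, and the limit now holds most of the series: the limit of > 100000 nM in this assay, at which 3 of the 4 values shown sit.

The compounds shown leave open whether that number in compound 1 rests on the aromatic ring or on its methoxy group, which a plain phenyl or a 4-chlorophenyl on that nitrogen would separate. They also leave open how far compound 2, compound 3 and compound 4 lie from one another beyond the limit.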